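A few compounds are considered here, and "the series" means these few. Any claim that something is new, unique, unknown or untested is made for them only; others in the source may bear on it.

Measured so far in a functional assay on SW-620 cells (Homo sapiens) for cytotoxicity, read by MTT assay, with a stated time of 48 h; a lower number here means a stronger inhibitor, a higher number a weaker inhibitor:

compound 1 `CCCCCCCCCCCCNC(=O)[C@@H](NC(=O)c1cc2ccccc2o1)[C@@H](C)O` gives 21300 nM
compound 2 `CCCCCCCCCCCCCCNC(=O)[C@@H](NC(=O)c1cc2ccccc2o1)[C@@H](C)O` gives 26700 nM
compound 3 `CCCCCCCCCCCCCCNC(=O)[C@@H](NC(=O)c1cc2ccccc2n1C)[C@@H](C)O` gives 21500 nM

Compound 2 holds the highest of the three numbers in this assay, but its neighbours sit close: a 1.3-fold higher number from compound 1 to compound 2 (0.10 log units; within the scatter) and a 1.2-fold lower number from compound 2 to compound 3 (0.09 log units; within the scatter) are both within the scatter, so no ordering among compounds 1, 2 and 3 can be read from these numbers.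

Compound 4 `CCCCCCCCCCCCCCNC(=O)[C@@H](NS(=O)(=O)c1ccc(C)cc1)[C@@H](C)O` is the next compound to be measured. Against compound 2 the change is (4-methylphenyl)sulfonyl in place of (1-benzofuran-2-yl)carbonyl on an amine nitrogen. Neither measured step touches this part of the molecule: the step from compound 1 to compound 2 alters the saturated chain, the step from compound 2 to compound 3 swaps one fused bicyclic acyl group for another fused bicyclic acyl group, and both stayed within the scatter. For the measured compounds named here, there is thus no measured step bearing directly on exchanging the whole acyl group for a sulfonyl group. Given how little the series has moved so far, the expectation is a step of a 1.1-fold higher number from compound 2 to compound 4 (0.05 log units; within the scatter) in this assay, not clearly beyond the scatter. Compound 4 is estimated at 30000 nM, within a range of 12000 nM to 80000 nM.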

Compound 4, half-maximal inhibitory concentration: 15200 nM
Compound 4: middle estimate off by 2.0-fold (0.30 log units), on the high side; the measured number falls inside the stated range.
By their numbers in this assay, from the lowest: compounds 4, 1, 3 and 2 (each within the scatter of the next).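

In this assay, the amine nitrogen of the shared core tolerates the exchange of its whole acyl group: a 1.8-fold lower number from compound 2 to compound 4 (0.24 log units; within the scatter) is the step measured at this position. Unlike the two earlier steps, this change replaces the carbonyl with a sulfonyl and the two-ring aromatic group with a single six-membered aromatic ring of carbon only, yet the step still stays within the scatter. No measured information on hand accounts for this result.

The step combines the linker exchange and the ring exchange, so a benzoyl group on the same nitrogen would be needed to read them apart. Also open, going by these compounds, is whether a methanesulfonyl group or a free amine at this position would give a step beyond the scatter.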